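A Methylsulfonyl Swap on Compound 3

This account rests on a few compounds, and the source may have more. Where it says the series, first, only, none or still open, it means among the compounds named here.

Of the compounds shown here, three sharing one core have been measured so far. In an ADME assay on microsomes from liver (Homo sapiens) for metabolic stability, using NADPH, with a stated time of 60 min, in the presence of a further agent that is not named here (on this read-out lower numbers stand for slow clearance and higher numbers for fast clearance), compound 1 `O=C(O)COc1ccc([C@H]2CC[C@]3(CC2)OOC2(O3)C3CC4CC2CC(C3)C4O)cc1` gives < 7 mL.min-1.g-1, which is a limit of the assay and not a number. Compound 2 `CC(=O)NC1C2CC3CC1CC(C2)C31OO[C@]2(CC[C@@H](c3ccc(OCC(=O)O)cc3)CC2)O1` gives 10 mL.min-1.g-1. Compound 3 `O=C(O)CNC(=O)COc1ccc([C@H]2CC[C@]3(CC2)OOC2(O3)C3CC4CC(C3)CC2C4)cc1` gives < 7 mL.min-1.g-1, again a limit and not a number, so compound 3 stands at the limit of < 7 mL.min-1.g-1 in this assay, at which 2 of the 3 values shown sit.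

Compound 4 `CS(=O)(=O)NC(=O)COc1ccc([C@H]2CC[C@]3(CC2)OOC2(O3)C3CC4CC(C3)CC2C4)cc1` has methylsulfonyl in place of carboxymethyl on an amide-type nitrogen. Within the data shown here, the only measured step is an at least 1.4-fold higher number from compound 1 to compound 2 (0.15 log units; that floor lies within the scatter). It comes from acetamido in place of hydroxy on a saturated ring carbon, which is a different change in a different place, and its floor lies within the scatter. Among the measured compounds shown here, no measured step covers the new change, so no shift beyond the scatter is expected in this assay. The expected step is a number no lower from compound 3 to compound 4 (the limit leaves the size open). Compound 4 is estimated at 7 mL.min-1.g-1, with an expected range from 4 mL.min-1.g-1 to 15 mL.min-1.g-1.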

Compound 4, intrinsic clearance in microsomes: < 7 mL.min-1.g-1
Compound 4 was reported as a limit (the forecaster's own chance of this, stated with the estimate: 60%); the middle value sits exactly at the limit.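

The step between compound 3 and compound 4 cannot be read, since both values in this assay are limits and not numbers: the limit of < 7 mL.min-1.g-1 in this assay, at which 3 of the 4 values shown sit.

The compounds shown leave open whether methylsulfonyl in place of carboxymethyl on the amide-type nitrogen changes clearance at all.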